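A few compounds are considered here, and "the series" means these few. Any claim that something is new, unique, unknown or untested is made for them only; others in the source may bear on it.

Of the compounds shown here, three sharing one core have been tested in an ADME assay on HEK293 cells (Homo sapiens) for cytotoxicity, with a stated time of 6 h; on this read-out lower numbers stand for higher toxicity in this test and higher numbers for lower toxicity in this test. Compound 1, `CNc1nc(N)nc2ccccc12`, carries the shortest side chain of the set. In this assay compound 1 gives > 25000 nM, which is a limit of the test rather than a number. Compound 2, `CCCCNc1nc(N)nc2cc(C(=O)N(C)C)ccc12`, has a longer chain and an amide on the core. In this assay compound 2 gives > 18000 nM, again a limit and not a number. Compound 3, `CCCCNc1nc(N)nc2cccc(OC)c12`, is the starting point of the step followed here. In this assay compound 3 gives > 25000 nM, once more a limit and not a number. Compound 3 therefore stands where the whole set stands: no value shown is a number, and the three results fall at two limits, namely the limit of > 25000 nM in this assay, at which 2 of the 3 values shown sit, and (the limit of > 18000 nM in this assay, at which 1 of the 3 values shown sits).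

Compound 4, `CCCCNc1nc(N)nc2cccc(C(=O)N(C)C(C)C)c12`, is still to be measured. It differs from compound 3 in one place: isopropyl(methyl)carbamoyl in place of methoxy on an aromatic carbon. For the measured compounds named here, no step between measured compounds exists to lean on, and every result so far is a limit, so the expected step that the limit leaves unreadable from compound 3 to compound 4 is none beyond the usual scatter. For compound 4 the estimate is 30000 nM, expected to lie between 12000 nM and 80000 nM, and the assay will most likely again report only a limit.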

Compound 4, half-maximal cytotoxic concentration: > 25000 nM
Compound 4 gave a limit, no number (the forecaster's own chance of this, stated with the estimate: 75%); the middle value does not contradict the limit.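

Compound 3 and compound 4 both give only a limit in this assay and not a number, so no step between them can be read: the limit of > 25000 nM in this assay, at which 3 of the 4 values shown sit.

The compounds shown leave open at what concentration any of them would become toxic to these cells, and whether isopropyl(methyl)carbamoyl in place of methoxy shifts that concentration at all.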